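A few compounds are considered here, and "the series" means these few. Any claim that something is new, unique, unknown or untested is made for them only; others in the source may bear on it.

Compound 1 `COc1cc(-n2cnc3ccc(-c4cccc(C)c4C)cc32)cc(OC)c1OC` is the starting point of this account. Within the data shown here, in a functional assay on MCF7 cells (Homo sapiens) for antiproliferative activity, read by MTT assay, with a stated time of 72 h (on this read-out higher numbers stand for weaker inhibition and lower numbers for stronger inhibition), compound 1 gives 2150 nM, the only number among the values shown. Compound 2 `COc1cc(-n2cnc3ccc(-c4ccccc4Cl)cc32)cc(OC)c1OC` differs from it in the phenyl group on the shared core. In this assay compound 2 gives > 10000 nM, which is a limit of the assay rather than a number (the limit of > 10000 nM in this assay, at which 1 of the 2 values shown sits). That change produced an at least 4.6-fold higher number from compound 1 to compound 2 (0.66 log units; beyond the scatter). Compound 3 `COc1cc(-n2cnc3ccc(-c4ccc(O)cc4)cc32)cc(OC)c1OC` carries the change (4-hydroxyphenyl in place of 2,3-dimethylphenyl on an aromatic carbon). Among the measured compounds shown here, the step from compound 1 to compound 2 is the only measured step that bears on it, since both exchange the 2,3-dimethylphenyl for a different phenyl, and it went toward weaker inhibition. A step in the same direction, of modest size, is therefore expected, a 2.1-fold higher number from compound 1 to compound 3 (0.32 log units; beyond the scatter). For compound 3 the expected value in this assay is 4500 nM, within a range of 1500 nM to 15000 nM.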

Compound 3, half-maximal inhibitory concentration: 4160 nM
For compound 3 the middle estimate is 1.1-fold (0.03 log units) above the measured one, within the range that was stated.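

In this assay the 4-hydroxyphenyl gives a 1.9-fold higher number from compound 1 to compound 3 (0.29 log units; within the scatter) and so cannot be told apart from the 2,3-dimethylphenyl, which shows that this position on the shared core tolerates a phenyl group bearing a hydrogen-bond donor and carrying its substituent para to the bond to the core. The exchange of 2-chlorophenyl for 4-hydroxyphenyl gives an at least 2.4-fold lower number from compound 2 to compound 3 (0.38 log units; beyond the scatter) and shows that the weak result of compound 2 does not extend to every phenyl group at this place. That step starts from compound 2, whose value is a limit of the assay and not a number: the limit of > 10000 nM in this assay, at which 1 of the 3 values shown sits.

On these data alone, what a 4-aminophenyl or a phenyl bearing a carboxylic acid would give at this position remains open. Also open, as far as these compounds go, is whether the hydroxyl itself contributes to the activity of compound 3.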